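The source may report more compounds than this note shows. Statements on the series, on what has been measured and on what is new or still open speak of the compounds shown alone.

Measured so far:
- compound 1, `O=C(COc1ccc2c(=O)ccoc2c1)Nc1cccc(NC(=O)c2ccc(Br)cc2)c1`, gives 303 nM in an assay on isolated protein for inhibition of Rho-associated protein kinase 1 (Homo sapiens), read by scintillation counting, radiometric assay and 33P incorporation, with a stated time of 40 min, in the presence of a further agent that is not named here; a higher number here means a weaker inhibitor, a lower number a stronger inhibitor
- compound 2, `O=C(COc1ccc2c(=O)ccoc2c1)Nc1cccc(NC(=O)c2ccc([N+](=O)[O-])cc2)c1`, gives 67 nM in this assay

Among the compounds with values here, of these two numbers, compound 2 stands lowest; its nearest neighbour is compound 1, and the one measured step, a 4.5-fold lower number from compound 1 to compound 2 (0.66 log units; beyond the scatter), lies beyond the usual scatter. That step shows that what sits on the aromatic ring next to the carbonyl can move the number by a modest amount.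

Compound 3, `Cc1cc(C(=O)Nc2cccc(NC(=O)COc3ccc4c(=O)ccoc4c3)c2)no1`, differs from compound 2 in one place: 5-methyl-1,2-oxazol-3-yl in place of 4-nitrophenyl on a carbonyl carbon. Within the data shown here, no measured step covers this exchange of the whole 4-nitrophenyl, so the expectation rests only on the modest step of a 4.5-fold lower number from compound 1 to compound 2 (0.66 log units; beyond the scatter), which shows that this part of the molecule matters. A somewhat weaker inhibition is expected, a 3.0-fold higher number from compound 2 to compound 3 (0.47 log units; beyond the scatter). For compound 3 the estimated value in this assay is 200 nM, with a range from 60 nM to 700 nM.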

Compound 3, half-maximal inhibitory concentration: 68 nM
Compound 3: the middle estimate sits 2.9-fold (0.47 log units) above what was measured; low and high end bracket the measured number.
By their numbers in this assay, from the lowest: compounds 2 and 3 (each within the scatter of the next); then compound 1.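

Exchanging the whole 4-nitrophenyl for 5-methyl-1,2-oxazol-3-yl, a group with fewer heavy atoms and a five-membered aromatic ring with 2 hetero atoms, leaves the number in place (a 1.0-fold higher number from compound 2 to compound 3 (0.01 log units; within the scatter)). Among these compounds, then, a six-membered aromatic ring of carbon only is not needed on this carbonyl carbon to reach the level of compound 2. The step from the 4-bromophenyl (a 4.5-fold lower number from compound 1 to compound 3 (0.65 log units; beyond the scatter)) closely matches the earlier nitro step in size, yet no evidence here explains why two such different groups give matching numbers. From the compounds shown here alone, it remains open how a plain phenyl, or a ring carrying an amine or a carboxylic acid, would behave on this carbonyl carbon. The contribution of the methyl on the five-membered ring is also unknown.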